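The source may hold more compounds than are shown below. What is called first, only, known or untested is meant among the compounds shown, and "the series" means these compounds.

In a functional assay on MCF7 cells (Homo sapiens) for antiproliferative activity, read by MTT assay, with a stated time of 72 h (a higher number here means a weaker inhibitor, a lower number a stronger inhibitor), compound 1 `O=C(COc1ccc(C(=O)/C=C/c2ccc(F)c(F)c2)cc1)N[C@H]1CCOC1=O` gives only a limit, > 64000 nM. Compound 2 `CC(C)c1ccc(/C=C/C(=O)c2ccc(OCC(=O)N[C@H]3CCOC3=O)cc2)cc1` gives 23400 nM, and compound 3 `O=C(COc1ccc(C(=O)/C=C/c2cccc(Br)c2)cc1)N[C@H]1CCOC1=O` gives 28300 nM. These two numbers lie within the scatter of each other, as a 1.2-fold higher number from compound 2 to compound 3 (0.08 log units; within the scatter) shows. Compound 4 `O=C(COc1ccc(C(=O)/C=C/c2cccc(F)c2)cc1)N[C@H]1CCOC1=O` follows from compound 3 by fluoro in place of bromo on an aromatic carbon, with fluoro in place of bromo on an aromatic carbon. The nearest measured change is an at least 2.2-fold lower number from compound 1 to compound 3 (0.35 log units; beyond the scatter), where 3-bromophenyl replaces 3,4-difluorophenyl, and an at least 2.7-fold lower number from compound 1 to compound 2 (0.43 log units; beyond the scatter) is similar in size. Returning to fluorine is therefore expected to raise the number modestly, and a reading at the limit remains possible. The expected change is a 1.5-fold higher number from compound 3 to compound 4 (0.17 log units; within the scatter). For compound 4 the estimated value is 42000 nM, with an expected range of 22000 nM to 64000 nM.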

Compound 4, half-maximal inhibitory concentration: > 64000 nM
Compound 4: a limit, no number; the forecaster's own chance of this, stated with the estimate: 30%; middle value at least 1.5-fold (0.18 log units) away from the limit.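

In this assay, fluoro in place of bromo on this aromatic carbon, meta to a large group, is a change beyond the scatter, an at least 2.2-fold higher number from compound 3 to compound 4 (0.35 log units; beyond the scatter), and an at least 2.7-fold higher number from compound 2 to compound 4 (0.43 log units; beyond the scatter) is a step of like direction, so a single atom here separates a measurable number from none. Going by these compounds, compound 4 gives only a limit, not a number, as compound 1 does: the limit of > 64000 nM in this assay, at which 2 of the 4 values shown sit. The step between those two limits cannot be read, so the second fluoro's contribution stays unknown.

On these data alone, whether chloro, methoxy or an amine at this position would give a number remains open. So does whether bromo at the other ring positions would match compound 3.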